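A few compounds are considered here, and "the series" means these few. Any claim that something is new, unique, unknown or untested is made for them only; others in the source may bear on it.

Measured so far in a functional assay (aorta) with Rattus norvegicus as the target; on this read-out lower numbers stand for stronger inhibition and higher numbers for weaker inhibition: compound 1 `CCO/C(O)=C1\C(COCCNc2n[nH]c(N)n2)=NC(C)=C(C(=O)OC)C1c1ccccc1Cl`, 20 nM; compound 2 `CCO/C(O)=C1\C(COCCNc2n[nH]c(N)n2)=NC(C)=C(C(=O)OC)C1c1cccnc1Cl`, 316 nM; compound 3 `CCO/C(O)=C1\C(COCCNc2n[nH]c(O)n2)=NC(C)=C(C(=O)OC)C1c1cccc(Cl)c1Cl`, 10 nM.

Compound 3 and compound 1 sit within the usual scatter of each other; compound 2 lies well beyond both. Going by the values given here, the single step between measured neighbours, a 16-fold higher number from compound 1 to compound 2 (1.20 log units; beyond the scatter), concerns the aryl group on the saturated ring carbon and is large.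

Compound 4 `CCO/C(O)=C1\C(COCCNc2nccnc2NC)=NC(C)=C(C(=O)OC)C1c1cccc(Cl)c1Cl` differs from compound 3 at the other end of the molecule: 3-(methylamino)pyrazin-2-yl in place of 5-hydroxy-1H-1,2,4-triazol-3-yl on an amine nitrogen. Among the compounds with values here, no measured step touches the amine substituent, so that large step gives no guidance here, and the shared core is otherwise unchanged. For compound 4 the expectation is therefore a 2.0-fold higher number from compound 3 to compound 4 (0.30 log units; within the scatter), nothing beyond the scatter, with an estimated 20 nM and a range of 6 nM to 70 nM.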

Compound 4, half-maximal inhibitory concentration: 5.01 nM
Estimate against measurement, compound 4: 4.0-fold (0.60 log units) above; measured number below the stated range.
By their numbers in this assay, from the lowest: compounds 4, 3 and 1 (each within the scatter of the next, the first and the last beyond it); then compound 2.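

In this assay, the amine nitrogen accepts 3-(methylamino)pyrazin-2-yl in place of 5-hydroxy-1H-1,2,4-triazol-3-yl with a 2.0-fold lower number from compound 3 to compound 4 (0.30 log units; within the scatter) on an otherwise unchanged molecule. Ring size, heavy-atom count and hydrogen-bond donor count all differ across this step, so this end of the series holds its low numbers with either of these two aromatic rings. Nothing available explains this result.

Open, from the compounds shown here alone, is whether a non-aromatic group, such as a methyl or an acetyl, would serve on the amine nitrogen. Also open, going by these compounds, is whether 2-chloropyridin-3-yl would raise the number as sharply with the pyrazine end.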